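Extending the thioester chain in a thiophene dihydropyrimidinone series

The source may hold more compounds than are shown below. What is called first, only, known or untested is meant among the compounds shown, and "the series" means these compounds.

Measured compounds:
Compound 1 `CC1=C(C(=O)NC(C)C)C(c2ccsc2)NC(=O)N1` gives 8%.
Compound 2 `CCSC(=O)C1=C(C)NC(=O)NC1c1ccsc1` gives 11%.

In an assay on membranes from CHO cells for displacement of a labelled ligand from adenosine receptor A1 (Homo sapiens), read by scintillation counting, with a stated time of 60 min, tested at 1 uM (on this read-out lower numbers stand for less inhibition and higher numbers for more inhibition at the one concentration tested (going by the name of the read-out)), compound 2 stands alongside compound 1, the step of a number 3 percentage points higher from compound 1 to compound 2 (within the scatter) being within the scatter, so neither can be set above the other. Compound 3 `CC1=C(C(=O)SC(C)C)C(c2ccsc2)NC(=O)N1` differs from compound 2 by methyl in place of hydrogen on a saturated chain carbon bound to a saturated chain carbon and a sulfur. For the measured compounds named here, no measured step bears directly on this change, since the only step known, a number 3 percentage points higher from compound 1 to compound 2 (within the scatter), concerns a different exchange on the carbonyl carbon. In this assay, compound 3 is therefore expected to show a number 1 percentage points higher from compound 2 to compound 3 (within the scatter), no step beyond the scatter. Compound 3 is estimated at 12%, between 0% and 25%.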

Compound 3, a percentage reported as inhibition, at one concentration (the size of the read-out at that concentration, not a potency): 24%
Compound 3: middle estimate off by 12 percentage points, on the low side, within the range that was stated.
By their numbers in this assay, from the lowest: compounds 1 and 2 (each within the scatter of the next); then compound 3.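

In this assay, methyl in place of hydrogen on a saturated chain carbon bound to a saturated chain carbon and a sulfur gives a number 13 percentage points higher from compound 2 to compound 3 (beyond the scatter), so the change from ethylsulfanyl to isopropylsulfanyl registers beyond the scatter. With isopropyl kept, going from the amide to the thioester gives a number 16 percentage points higher from compound 1 to compound 3 (beyond the scatter), an exchange that the ethylsulfanyl compound had not separated from the amide. No evidence is at hand on what lies behind either step. The compounds shown leave open whether tert-butylsulfanyl or a longer chain on the sulfur would change the number further. They also give no potency, only the inhibition at one concentration.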